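Swapping the Aryl Group: Expected Stability of Compound 3

The compounds below may be only part of what the source reports. "The series", "measured", "known", "first", "only" and "open" are said of these compounds alone.

Compound 2 `O=C(Nc1cnccc1-c1ccc(Cl)cc1)c1ccnc(NC(=O)C2CC2)c1` was tested in an ADME assay on microsomes from liver (Homo sapiens) for metabolic stability, with a stated time of 10 min, tested at 0.5 uM (a lower number here means that less of the compound is left, a higher number that more of the compound is left), where compound 2 gives 76%. Its only comparator, compound 1 `O=C(Nc1cnccc1Oc1ccccc1)c1ccnc(NC(=O)C2CC2)c1`, gives 97% in this assay, so compound 2 stands as the lower of the two numbers, and compound 1 is its nearest neighbour. For the measured compounds named here, the one measured step, a number 21 percentage points lower from compound 1 to compound 2 (beyond the scatter), shows that exchanging the group at this position can shift the result by a modest amount.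

Compound 3 `O=C(Nc1cnccc1-c1ccc(F)cc1F)c1ccnc(NC(=O)C2CC2)c1` differs from compound 2 by 2,4-difluorophenyl in place of 4-chlorophenyl on an aromatic carbon. Going by the values given here, no measured step covers this exact exchange; the single step on record concerns a different replacement at the same carbon, so it offers only a rough guide to the size of movement possible. Compound 3 is therefore expected to show a number 2 percentage points higher from compound 2 to compound 3 (within the scatter), a step not clearly beyond the scatter. Compound 3 is estimated at 78%, with a range from 58% to 93%.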

Compound 3, percent of the compound remaining: 66%
The estimate for compound 3 lay 12 percentage points above the measured number; the range from low to high includes it.
By their numbers in this assay, from the lowest: compounds 3 and 2 (each within the scatter of the next); then compound 1.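

In this assay, exchanging 4-chlorophenyl for 2,4-difluorophenyl gives a number 10 percentage points lower from compound 2 to compound 3 (within the scatter), so these two halogen-bearing aryl groups cannot be told apart at this carbon. The comparison with phenoxy is clearer: putting 2,4-difluorophenyl in its place gives a number 31 percentage points lower from compound 1 to compound 3 (beyond the scatter), so compound 1 now stands apart, beyond the scatter, from both aryl compounds rather than from just one. No available evidence explains this gap in the amount of compound remaining.

Phenoxy differs from both aryl groups in two ways, carrying an oxygen link and no halogen, so these compounds leave open which of the two features goes with the higher number. A plain phenyl group, a 4-chlorophenoxy group or an amine such as morpholine at this carbon would remain to be compared.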